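Varying the para substituent on the ketone-bearing ring

The source may hold more compounds than are shown below. What is called first, only, known or untested is meant among the compounds shown, and "the series" means these compounds.

Measured compounds:
compound 1 `CCCCCCCCCCCCOc1ccc(C(=O)/C=C/c2c(/C=C/c3ccc(OC)cc3)cc(OC)cc2OC)cc1` 11.6 ug/mL
compound 2 `CCCC(C)Oc1ccc(C(=O)/C=C/c2c(/C=C/c3ccc(OC)cc3)cc(OC)cc2OC)cc1` 11.1 ug/mL
compound 3 `COc1ccc(/C=C/c2cc(OC)cc(OC)c2/C=C/C(=O)c2ccc(N)cc2)cc1` 7.5 ug/mL

In a functional assay on HepG2 cells (Homo sapiens) for antiproliferative activity, read by MTT assay, with a stated time of 48 h (a higher number here means a weaker inhibitor, a lower number a stronger inhibitor), the three compounds give numbers that sit close together. Compound 3 gives the lowest of the three, but a 1.5-fold lower number from compound 2 to compound 3 (0.17 log units; within the scatter) is within the scatter, as is a 1.0-fold lower number from compound 1 to compound 2 (0.02 log units; within the scatter), so none of the three can be called stronger or weaker than another.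

Compound 4 `CCN(CC)c1ccc(C(=O)/C=C/c2c(/C=C/c3ccc(OC)cc3)cc(OC)cc2OC)cc1` carries the change (diethylamino in place of amino on an aromatic carbon). Both earlier steps bear on it, since each also replaced the group at this same place on the ring, and neither moved the number beyond the scatter. Nothing in the series suggests that the group at this position shifts the result, so the expected step of a 1.1-fold higher number from compound 3 to compound 4 (0.05 log units; within the scatter) is none beyond the scatter. Among the measured compounds shown here, compound 4 is therefore estimated at 8.5 ug/mL in this assay, with a range from 4.5 ug/mL to 16 ug/mL, the width reflecting that only three compounds, all near one value, inform the estimate.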

Compound 4, half-maximal inhibitory concentration: 6.3 ug/mL
Compound 4: middle estimate off by 1.3-fold (0.13 log units), on the high side; the range from low to high includes it.
By their numbers in this assay, from the lowest: compounds 4, 3, 2 and 1 (each within the scatter of the next).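

Read in this assay the change to diethylamino gives a 1.2-fold lower number from compound 3 to compound 4 (0.08 log units; within the scatter) and so leaves no readable difference, even though a group of 5 heavy atoms with 0 hydrogen-bond donors replaces one of 1 heavy atom with 1 hydrogen-bond donor. Likewise a 1.8-fold lower number from compound 2 to compound 4 (0.25 log units; within the scatter) comes with diethylamino in place of 1-methylbutoxy, so exchanging the oxygen-linked group for a nitrogen-linked one at this position also gives no readable difference. No measurement is available that would explain why these groups give such similar numbers.

From the compounds shown here alone, whether any group at this position can move the number beyond the scatter remains open, for instance a carboxylic acid or a nitrile on the aromatic carbon. The series also leaves open how the number responds to changes elsewhere on the shared core, such as replacing a methoxy group with a hydroxyl group.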